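The source may report more compounds than this note shows. Statements on the series, on what has been measured and on what is new or still open speak of the compounds shown alone.

Compound 1 `COc1cc2ncnc(Nc3ccc(Br)cc3)c2cc1OCCCCC(=O)Nc1ccc(S(N)(=O)=O)cc1`: > 40000 nM
Compound 2 `COc1ccc(Nc2ncnc3cc(OC)c(OCCCCC(=O)Nc4ccc(S(N)(=O)=O)cc4)cc23)cc1OC`: > 40000 nM
Compound 3 `COc1cc2ncnc(Nc3cccc(Cl)c3F)c2cc1OCCCCC(=O)Nc1ccc(S(N)(=O)=O)cc1`: 10500 nM

Within the data shown here, in a functional assay on A549 cells (Homo sapiens) for antiproliferative activity, read by MTT assay, with a stated time of 72 h (on this read-out lower numbers stand for stronger inhibition and higher numbers for weaker inhibition), compound 3 gives 10500 nM, the only value that is a number. Compound 1 gives > 40000 nM, which is a limit of the assay. Compound 2 gives > 40000 nM, also a limit. Compound 4 `COc1ccccc1Nc1ncnc2cc(OC)c(OCCCCC(=O)Nc3ccc(S(N)(=O)=O)cc3)cc12` differs from compound 3 in one place: 2-methoxyphenyl in place of 3-chloro-2-fluorophenyl on a nitrogen on an aromatic ring. Among the measured compounds shown here, two measured steps bear on this exchange: an at least 3.8-fold lower number from compound 1 to compound 3 (0.58 log units; beyond the scatter) and an at least 3.8-fold lower number from compound 2 to compound 3 (0.58 log units; beyond the scatter). Both show that replacing the 3-chloro-2-fluorophenyl group by another phenyl group has so far raised the number at least modestly, and compound 2, which carries a methoxy-bearing phenyl, sits at the limit of > 40000 nM in this assay, at which 2 of the 3 values shown sit. A higher number is therefore expected for compound 4, with a 2.9-fold higher number from compound 3 to compound 4 (0.46 log units; beyond the scatter). The estimate for compound 4 is 30000 nM, ranging from 8000 nM to 100000 nM.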

Compound 4, half-maximal inhibitory concentration: 24100 nM
Estimate against measurement, compound 4: 1.2-fold (0.10 log units) above; low and high end bracket the measured number.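

In this assay there is a 2.3-fold higher number from compound 3 to compound 4 (0.36 log units; beyond the scatter), so a methoxy-bearing phenyl group on this nitrogen can give a measured value, yet 3-chloro-2-fluorophenyl still gives the lower number. Compound 4 cannot be separated from the other two, with an at least 1.6-fold lower number from compound 2 to compound 4 (0.22 log units; that floor lies within the scatter) and an at least 1.6-fold lower number from compound 1 to compound 4 (0.22 log units; that floor lies within the scatter). Compounds 1 and 2 give limits of the assay, not numbers: the limit of > 40000 nM in this assay, at which 2 of the 4 values shown sit.

Going by these compounds, how a plain phenyl or a chlorophenyl group would read on this nitrogen stays open. So does the effect of a longer chain on the other side of the core.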